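A few compounds are considered here, and "the series" means these few. Any claim that something is new, unique, unknown or untested is made for them only; others in the source may bear on it.

Series notes. In an assay on HEK293 cells for agonist activity at transient receptor potential cation channel subfamily M member 8 (Homo sapiens), read by fluorescence and calcium flux, with a stated time of 15 min (on this read-out lower numbers stand for an effect already at smaller amounts and higher numbers for an effect only at larger amounts of compound), compound 1 `CCc1ccc(OCC(=O)N(CC)Cc2cccs2)cc1` gives 67 nM, compound 2 `CCN(Cc1cccs1)C(=O)c1cc2cc(C)ccc2[nH]1` gives 2010 nM, and compound 3 `Cc1ccc(OCC(=O)N(Cc2cccs2)C2CCCCC2)cc1` gives 40000 nM. Compound 3 thus carries the highest number of the three; its gap to compound 2 lies beyond the scatter, and its gap to compound 1 is wider still. Compound 4 `Cc1ccc(OCC(=O)N(Cc2cccs2)c2nccn2C)cc1` differs from compound 3 in one place: 1-methyl-1H-imidazol-2-yl in place of cyclohexyl on an amide-type nitrogen. The entering group is aromatic, with two hetero atoms and two hydrogen-bond acceptors, sitting on the amide-type nitrogen whose other neighbours are a carbonyl carbon and a saturated chain carbon. For the measured compounds named here, no measured pair carries this change, so the step is uncertain; a modest move toward a lower number in this assay is expected, estimated as a 3.3-fold lower number from compound 3 to compound 4 (0.52 log units; beyond the scatter). Compound 4 is accordingly expected to give about 12000 nM, within 3000 nM to 40000 nM.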

Compound 4, half-maximal effective concentration: 1790 nM
The estimate for compound 4 lay 6.7-fold (0.83 log units) above the measured number; the measured number lies below the stated range.
By their numbers in this assay, from the lowest: compound 1; then compounds 4 and 2 (each within the scatter of the next); then compound 3.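

In this assay the exchange of cyclohexyl for 1-methyl-1H-imidazol-2-yl on the amide-type nitrogen gives a 22-fold lower number from compound 3 to compound 4 (1.35 log units; beyond the scatter) and shows that the number responds strongly to the group at this position. Both groups have the same count of heavy atoms, so the step comes with a change in ring type, hetero atoms and hydrogen-bond acceptors, not in heavy-atom count. No data at hand explain the size of the step. Still open, as far as these compounds go, is whether the aromatic ring alone or its ring nitrogens carry the step. A phenyl or pyridin-2-yl group on this nitrogen would separate the two.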